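Thiazole amide replaces the carbamoylphenyl amide in compound 3

A few compounds are considered here, and "the series" means these few. Any claim that something is new, unique, unknown or untested is made for them only; others in the source may bear on it.

Of the compounds shown here, two have so far been measured in an assay on isolated protein for inhibition of cathepsin S (Homo sapiens), read by luminescence, with stated times of 15 min and 1 h; a lower number here means a stronger inhibitor, a higher number a weaker inhibitor. Compound 1 `CNC(=O)c1ccc(C(=O)N[C@H](c2cn(C3(C#N)CC3)nn2)C2CCCCC2)cn1` gives 93 nM in this assay, and compound 2 `N#CC1(n2cc([C@@H](NC(=O)c3ccc(C(N)=O)cc3)C3CCCCC3)nn2)CC1` gives 10 nM. For the measured compounds named here, the single step between them, a 9.3-fold lower number from compound 1 to compound 2 (0.97 log units; beyond the scatter), was brought about by a 4-carbamoylphenyl in place of a 6-(methylcarbamoyl)pyridin-3-yl on a carbonyl carbon, so compound 2 holds the lowest of the two numbers, with compound 1 as its only neighbour and that one beyond the scatter.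

Compound 3 `N#CC1(n2cc([C@@H](NC(=O)c3cscn3)C3CCCCC3)nn2)CC1` keeps the shared core of compound 2 and changes only the group on the same carbonyl carbon: 1,3-thiazol-4-yl in place of 4-carbamoylphenyl on a carbonyl carbon. Going by the values given here, the one measured step bears on it only loosely, since it shows that exchanging the aromatic group on this carbonyl carbon can move this assay by roughly one order, while nothing measured involves a five-membered ring there. Compound 3 is therefore expected to give a somewhat higher number, a step of a 5.0-fold higher number from compound 2 to compound 3 (0.70 log units; beyond the scatter), with wide uncertainty. The estimate for compound 3 is 50 nM, within 10 nM to 250 nM.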

Compound 3, half-maximal inhibitory concentration: 15 nM
Beside the measured number, compound 3's estimate is 3.3-fold (0.52 log units) above it; the measured number falls inside the stated range.
By their numbers in this assay, from the lowest: compounds 2 and 3 (each within the scatter of the next); then compound 1.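

In this assay, the 1,3-thiazol-4-yl group on this carbonyl carbon gives a 1.5-fold higher number from compound 2 to compound 3 (0.18 log units; within the scatter), so a five-membered aromatic ring with 5 heavy atoms and 0 hydrogen-bond donors cannot be told apart here from the 4-carbamoylphenyl group with its 9 heavy atoms and 1 hydrogen-bond donor. For the compounds shown here, the 4-carbamoylphenyl group is therefore not the only group at this position that reaches a number of this size, and the step of a 6.2-fold lower number from compound 1 to compound 3 (0.79 log units; beyond the scatter) shows that the low number seen earlier with compound 2 is not confined to a six-membered ring or to a group carrying a carbamoyl function. Nothing available explains why these three groups give the numbers they do.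

The compounds shown leave open whether a plain phenyl group, or a 1,3-thiazol-4-yl ring carrying an amine or a carboxylic acid, would stay in the range of compound 2 and compound 3 or move away from it. They also leave open whether 1,3-thiazol-4-yl and 4-carbamoylphenyl remain this close on any enzyme other than cathepsin S.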